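The compounds below may be only part of what the source reports. "The series", "measured", "known", "first", "only" and "open" are said of these compounds alone.

Compound 1 `CN(C)c1ncnc2c1c(-c1cc3ccccc3o1)cn2[C@@H]1O[C@H](CO)[C@@H](O)[C@H]1O` gives > 100000 nM in an ADME assay on MRC5 cells (Homo sapiens), read by MTT assay, with a stated time of 72 h (a higher number here means a weaker inhibitor, a lower number a stronger inhibitor), which is a limit of the assay rather than a number.
Compound 2 `C#Cc1cn([C@@H]2O[C@H](CO)[C@@H](O)[C@H]2O)c2ncnc(N(C)C)c12` gives 36100 nM in this assay.
Compound 3 `Cc1nc(N)c2c(-c3ccsc3)cn([C@@H]3O[C@H](CO)[C@@H](O)[C@H]3O)c2n1` gives > 100000 nM in this assay, again a limit of the assay.

Compound 1 therefore stands at the limit of > 100000 nM in this assay, at which 2 of the 3 values shown sit, and only a limit is known for it. Going by the values given here, the single measured step, an at least 2.7-fold lower number from compound 1 to compound 2 (0.44 log units; beyond the scatter), changes a different group at a different place, so it does not bear on the change to compound 4 `COc1ncnc2c1c(-c1cc3ccccc3o1)cn2[C@@H]1O[C@H](CO)[C@@H](O)[C@H]1O`. That change is methoxy in place of dimethylamino on an aromatic carbon. Among the compounds with values here, with no measured step bearing on it, no step beyond the scatter is expected in this assay. Compound 4 is therefore expected to stay at the limit, estimated near 150000 nM with a range of 50000 nM to 500000 nM. This estimate means an expected step that the limit leaves unreadable from compound 1 to compound 4.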

Compound 4, half-maximal inhibitory concentration: 65600 nM
For compound 4 the middle estimate is 2.3-fold (0.36 log units) above the measured one; measured number inside the range.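

Compound 4 shows that, with 1-benzofuran-2-yl kept, a number can be read in this assay once methoxy replaces dimethylamino on this aromatic carbon. The change gives an at least 1.5-fold lower number from compound 1 to compound 4 (0.18 log units; that floor lies within the scatter), so what can be read does not yet stand clear of the scatter. Its true size stays unknown because compound 1 rests on a limit: the limit of > 100000 nM in this assay, at which 2 of the 4 values shown sit.

Still open, as far as these compounds go, is what a longer ether such as ethoxy, or a cyclic amine such as morpholine, would give at this place. From the compounds shown here alone, whether methoxy would act the same way alongside the ethynyl group of compound 2 is also open.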